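Hydroxamic acid chain series: aminobenzoxazole in place of azaindole

The source may report more compounds than this note shows. Statements on the series, on what has been measured and on what is new or still open speak of the compounds shown alone.

Measured so far:
compound 1, `Nc1ncnc2c1c(-c1cnc3[nH]ccc3c1)nn2CCCCCCCCC(=O)NO` — 7500 nM
compound 2, `Nc1ncnc2c1c(-c1cnc3[nH]ccc3c1)nn2CCCCCC(=O)NO` — "not determined" (no result reported)

Among the compounds with values here, in a functional assay on SNU-423 cells (Homo sapiens) for inhibition, read by MTT assay, with a stated time of 72 h (on this read-out lower numbers stand for stronger inhibition and higher numbers for weaker inhibition), compound 1 gives 7500 nM, the only number in the set; compound 2 has "not determined" (no result reported) there, so no step between measured compounds exists. Compound 3, `Nc1nc2cc(-c3nn(CCCCCCCCC(=O)NO)c4ncnc(N)c34)ccc2o1`, differs from compound 1 by a group of 10 heavy atoms (7 carbon, 2 nitrogen, 1 oxygen; one five-membered aromatic ring with 2 hetero atoms, one six-membered aromatic ring of carbon only) in place of a group of 9 heavy atoms (7 carbon, 2 nitrogen; one five-membered aromatic ring with 1 hetero atom, one six-membered aromatic ring with 1 hetero atom), on an aromatic carbon, the new group entering on an aromatic carbon of the shared core while the nonanoyl hydroxamic chain is kept. Within the data shown here, with no measured step to anchor on, only a small shift is expected, and compound 3 is estimated at 9000 nM, between 3000 nM and 27000 nM. The expected step from compound 1 is a 1.2-fold higher number from compound 1 to compound 3 (0.08 log units; within the scatter), not clearly beyond the scatter.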

Compound 3, half-maximal inhibitory concentration: 4940 nM
Beside the measured number, compound 3's estimate is 1.8-fold (0.26 log units) above it; the range from low to high includes it.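

In this assay, 2-amino-1,3-benzoxazol-5-yl on this aromatic carbon of the shared core, with the nonanoyl hydroxamic chain kept, gives a 1.5-fold lower number from compound 1 to compound 3 (0.18 log units; within the scatter) as its step. This position therefore takes either group without a step beyond the scatter, and this read-out does not separate them. No supporting data bear on this result. Still open, from the compounds shown here alone, is whether a plain phenyl at this position, or a carboxylic acid in place of the hydroxamic acid, would move the number beyond the scatter.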